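Swapping the Methylpiperazinyl Arm for an Imidazolyl Group

The source may report more compounds than this note shows. Statements on the series, on what has been measured and on what is new or still open speak of the compounds shown alone.

Measured compounds:
compound 1 `CN1CCN(c2ccc(C3=NN(C(=O)c4ccc(C(F)(F)F)cc4)C(c4ccc(N(C)C)cc4)C3)cc2)CC1`: 84.1%
compound 2 `Cc1ccc(S(=O)(=O)N2N=C(c3ccc(N4CCN(C)CC4)cc3)CC2c2ccc(N(C)C)cc2)cc1`: 32.2%
compound 3 `CN1CCN(c2ccc(C3=NN(S(=O)(=O)c4ccc(C(F)(F)F)cc4)C(c4ccc(N(C)C)cc4)C3)cc2)CC1`: 27%

All three were tested in a functional assay on HCC1806 cells (Homo sapiens) for inhibition, read by sulforhodamine B assay, tested at 10 uM; a higher number here means more inhibition at the concentration tested (going by the name of the read-out), a lower number less inhibition. Compound 2 stands second highest of the three: the nearest value is a number 5.2 percentage points lower from compound 2 to compound 3 (within the scatter), a gap within the scatter, while the larger gap is a number 51.9 percentage points lower from compound 1 to compound 2 (beyond the scatter), beyond it. Compound 4 `Cc1ccc(S(=O)(=O)N2N=C(c3ccc(-n4ccnc4)cc3)CC2c2ccc(N(C)C)cc2)cc1` is not yet measured. It differs from compound 2 in one place: 1H-imidazol-1-yl in place of 4-methylpiperazin-1-yl on an aromatic carbon. Neither measured step touches this group; one concerns the substituent on the ring nitrogen and was large, the other a methyl versus trifluoromethyl change and was within the scatter. Among the compounds with values here, no measured step therefore speaks to this change, so there is no basis for expecting a shift beyond the scatter. Compound 4 is thus estimated at 30%, with a range from 10% to 55%. For compound 4 the expected step is a number 2.2 percentage points lower from compound 2 to compound 4 (within the scatter).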

Compound 4, a percentage reported as inhibition, at one concentration (the size of the read-out at that concentration, not a potency): 66%
The estimate for compound 4 lay 36 percentage points below the measured number; measured number above the stated range.
By their numbers in this assay, from the lowest: compounds 3 and 2 (each within the scatter of the next); then compound 4; then compound 1.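

In this assay, within the data shown here, the change on the aromatic carbon gives a number 33.8 percentage points higher from compound 2 to compound 4 (beyond the scatter), so this position also moves the read-out, which the earlier steps at the ring nitrogen and the methyl-bearing carbon could not show. The swap replaces a six-membered non-aromatic ring with a five-membered aromatic ring, while the counts of hydrogen-bond donors and acceptors stay the same. No measurement here explains the rise. Still open, on these data alone, is whether morpholin-4-yl or 1H-pyrazol-1-yl would behave like 1H-imidazol-1-yl here. Also open, as far as these compounds go, is whether 1H-imidazol-1-yl would give a similar step alongside the carbonyl group of compound 1.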